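The compounds below may be only part of what the source reports. "The series", "measured", "known", "first", "only" and "open" are said of these compounds alone.

Compound 1 `ClCc1ccccc1Cn1cnc2c(Cl)nc(Cl)nc21` and compound 3 `ClCc1ccc(Cn2cnc3nc(Cl)nc(Cl)c32)cc1` are built from the same atoms joined differently; the difference between their two cores is not broken down here. In a functional assay on SF-539 cells (Homo sapiens) for cytotoxicity, read by sulforhodamine B assay, with a stated time of 48 h (a lower number here means a stronger inhibitor of growth, a higher number a weaker inhibitor of growth), compound 1 gives 2880 nM, and compound 3 gives 3310 nM, two numbers that lie within the usual scatter of each other. Compound 2 `ClCc1ccccc1Cn1cnc2c(Cl)ncnc21` arises from compound 1 by hydrogen in place of chloro on an aromatic carbon, and in this assay compound 2 gives 24000 nM, a step of an 8.3-fold higher number from compound 1 to compound 2 (0.92 log units; beyond the scatter) that stands well beyond the scatter. Compound 4 `ClCc1ccc(Cn2cnc3ncnc(Cl)c32)cc1` has not yet been measured. It is related to compound 3 by hydrogen in place of chloro on an aromatic carbon, the same change at a place described in the same words as for compound 1 and compound 2. The expectation for compound 4 in this assay rests on the step of an 8.3-fold higher number from compound 1 to compound 2 (0.92 log units; beyond the scatter), the only precedent for this change among these compounds, and on compound 3 giving 3310 nM. For compound 4 a step of an 8.2-fold higher number from compound 3 to compound 4 (0.91 log units; beyond the scatter) is expected. Compound 4 is therefore estimated at 27000 nM, within a range from 9000 nM to 80000 nM.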

Compound 4, concentration for total growth inhibition: 3710 nM
Estimate against measurement, compound 4: 7.3-fold (0.86 log units) above; the measured number lies below the stated range.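

In this assay, hydrogen in place of chloro on an aromatic carbon gives a 1.1-fold higher number from compound 3 to compound 4 (0.05 log units; within the scatter), so the large step seen on the core of compound 1 does not recur on the core of compound 3. Set side by side, the two steps do not agree: the same change on two cores in this assay, an 8.3-fold higher number (0.92 log units; beyond the scatter) from compound 1 to compound 2 and a 1.1-fold higher number (0.05 log units; within the scatter) from compound 3 to compound 4, 7.4-fold (0.87 log units) apart, beyond the scatter of two such steps. This shows that, for these two pairs, the size of the step cannot be carried from one core to the other, but it does not show which part of the difference between the two cores accounts for this, and two pairs give no rule for any further core.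

The compounds shown leave open how an amine or a methoxy group on that same aromatic carbon, between two ring nitrogen atoms, would compare with chloro and hydrogen on either core. Also open, from the compounds shown here alone, is what would follow if a hydroxymethyl group took the place of the chloromethyl group that all four compounds carry.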